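Benzylation of the aminomethyl side chain in compound 2

The source may hold more compounds than are shown below. What is called first, only, known or untested is meant among the compounds shown, and "the series" means these compounds.

Series notes. The parent, compound 1 `COc1cc2c(cc1OC)C(=O)/C(=C/c1cccc(O)c1)CO2`, carries a hydrogen on the aromatic carbon that later bears the aminomethyl groups; in an assay on isolated protein for inhibition of Amine oxidase [flavin-containing] B (Homo sapiens), read by fluorescence, with a stated time of 30 min (a higher number here means a weaker inhibitor, a lower number a stronger inhibitor), compound 1 gives 190 nM. Compound 2 `COc1cc2c(cc1OC)C(=O)/C(=C/c1ccc(CN(C)C)c(O)c1)CO2` gives 882 nM in this assay, and compound 3 `COc1cc2c(cc1OC)C(=O)/C(=C/c1ccc(CN3CCCC3)c(O)c1)CO2` gives 722 nM. Within these three numbers compound 2 stands highest; its nearest neighbour is compound 3, with which it lies within the scatter, and its furthest is compound 1, a 4.6-fold higher number from compound 1 to compound 2 (0.67 log units; beyond the scatter). The related step of a 3.8-fold higher number from compound 1 to compound 3 (0.58 log units; beyond the scatter) is of similar size, while a 1.2-fold lower number from compound 2 to compound 3 (0.09 log units; within the scatter), so exchanging one amine for another at the saturated chain carbon left the number essentially unmoved.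

Compound 4 `COc1cc2c(cc1OC)C(=O)/C(=C/c1ccc(CN(C)Cc3ccccc3)c(O)c1)CO2` is the next point. Relative to compound 2 the change is phenyl in place of hydrogen on a saturated chain carbon bound to an amine nitrogen. The step that bears most directly on it is the amine exchange from compound 2 to compound 3, which stayed within the scatter; the two steps from compound 1 show that additions at this side chain have so far cost only modestly. A change at the amine is therefore expected to move the number little, if at all, beyond the scatter, with any drift toward a higher number. The estimate for compound 4 is 1000 nM, range 400 nM to 2500 nM, which means an expected step of a 1.1-fold higher number from compound 2 to compound 4 (0.05 log units; within the scatter).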

Compound 4, half-maximal inhibitory concentration: 1150 nM
Estimate against measurement, compound 4: 1.2-fold (0.06 log units) below, within the range that was stated.
By their numbers in this assay, from the lowest: compound 1; then compounds 3, 2 and 4 (each within the scatter of the next).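

In this assay, phenyl in place of hydrogen on a saturated chain carbon bound to an amine nitrogen turns methyl into benzyl and gives a 1.3-fold higher number from compound 2 to compound 4 (0.12 log units; within the scatter), while benzyl(methyl)amino in place of pyrrolidin-1-yl gives a 1.6-fold higher number from compound 3 to compound 4 (0.20 log units; within the scatter). The amine end of the side chain therefore accepts an added six-membered aromatic ring without a number that can be separated from those of compound 2 and compound 3, whereas the full (benzyl(methyl)amino)methyl group in place of hydrogen on an aromatic carbon gives a 6.1-fold higher number from compound 1 to compound 4 (0.78 log units; beyond the scatter), so among the compounds shown, the gap to the parent goes with the presence of an aminomethyl side chain and is not resolved by the choice of amine. No measurement at hand bears on the reason for this behaviour.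

Still open, on these data alone, is whether a longer chain on the amine, such as phenethyl, or a benzyl ring carrying fluorine, also stays within the scatter of compound 4. Equally open, as far as these compounds go, is whether the number moves back toward compound 1 at 190 nM with an amide or a morpholine in place of these amines.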